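A few compounds are considered here, and "the series" means these few. Any claim that something is new, unique, unknown or untested is made for them only; others in the source may bear on it.

Compounds measured:
- compound 1 `Cc1cccc(Cc2cnc(CCc3ccc(-c4ccccc4C(=O)O)cc3)[nH]2)c1`, in an in vitro functional assay on cells for agonist activity at Bombesin receptor subtype-3 (Mus musculus), read by luminescence and calcium flux (on this read-out higher numbers stand for an effect only at larger amounts of compound and lower numbers for an effect already at smaller amounts), compound 1 gives 75 nM
- compound 2 `N#Cc1ccccc1Cc1cnc(CCc2ccc(-c3ccccc3C(=O)O)cc2)[nH]1`, in this assay compound 2 gives 642 nM
- compound 3 `CC(C)(C)c1cnc(CCc2ccc(-c3ccccc3C(=O)O)cc2)[nH]1`, in this assay compound 3 gives 2750 nM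

Compound 3 stands at the highest number of the three, with compound 2 the nearest and compound 1 the furthest from it. Compound 4 `COc1cccc(Cc2cnc(CCc3ccc(-c4ccccc4C(=O)O)cc3)[nH]2)c1` differs from compound 3 in one place: 3-methoxybenzyl in place of tert-butyl on an aromatic carbon. Among the compounds with values here, two measured steps bear on this change, both running the other way: a 37-fold higher number from compound 1 to compound 3 (1.56 log units; beyond the scatter) and a 4.3-fold higher number from compound 2 to compound 3 (0.63 log units; beyond the scatter). Both replacements of a benzyl group on that aromatic carbon by tert-butyl raised the number beyond the scatter, the 3-methylbenzyl case by far the more. The 3-methoxybenzyl group of compound 4 shares its ring and its substitution pattern with the 3-methylbenzyl group of compound 1 rather than with the 2-cyanobenzyl group of compound 2, so the step expected for compound 4 in this assay is a large fall, of the order seen in the reverse of compound 1 to compound 3, though a methoxy group has not itself been tested here and a smaller fall of the size seen between compound 2 and compound 3 cannot be excluded. Compound 4 is therefore estimated at 130 nM, within 40 nM to 450 nM, which would mean a step of a 21-fold lower number from compound 3 to compound 4 (1.33 log units; beyond the scatter).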

Compound 4, half-maximal effective concentration: 79 nM
The estimate for compound 4 lay 1.6-fold (0.22 log units) above the measured number; the range from low to high includes it.
By their numbers in this assay, from the lowest: compounds 1 and 4 (each within the scatter of the next); then compound 2; then compound 3.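

In this assay, the 3-methoxybenzyl group on this aromatic carbon gives a 35-fold lower number from compound 3 to compound 4 (1.54 log units; beyond the scatter) and so shows that a benzyl group carrying an oxygen-linked substituent can take the place of tert-butyl here, while methoxy in place of methyl gives a 1.1-fold higher number from compound 1 to compound 4 (0.02 log units; within the scatter) and so leaves compound 1 and compound 4 within the scatter of each other. Within the data shown here, the 2-cyanobenzyl group of compound 2 now stands apart from both of these benzyl groups, with an 8.1-fold lower number from compound 2 to compound 4 (0.91 log units; beyond the scatter) adding a second step of similar size to the one already seen from compound 1, although that comparison changes both the substituent and where it sits on the benzyl ring. Nothing given here accounts for these steps.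

The compounds shown do not separate the effect of the nitrile from that of its place on the ring, since no nitrile stands where methyl and methoxy stand, and no methyl or methoxy stands where the nitrile does. They also leave open how an unsubstituted benzyl group, an amine or carboxylic acid on the benzyl ring, or a longer chain in place of the benzyl carbon would fare at this position.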